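Moving a methyl group around a benzyl ether ring

The source may hold more compounds than are shown below. What is called first, only, known or untested is meant among the compounds shown, and "the series" means these compounds.

Two compounds have numbers in hand. Compound 1 `Cc1cccc(C)c1-c1cccc(COc2ccc(CCC(=O)O)s2)c1` is measured in a functional assay on CHO cells for agonist activity at Free fatty acid receptor 1 (Homo sapiens), read by calcium flux (on this read-out lower numbers stand for an effect already at smaller amounts and higher numbers for an effect only at larger amounts of compound), and gives 52 nM. Compound 2 `CCOC(CC(=O)O)c1ccc(OCc2ccccc2C)cc1` in this assay gives 20 nM. Of these two numbers, compound 2 carries the lower one, and the gap up to compound 1 lies beyond the usual scatter of repeated measurements, so the two compounds are genuinely told apart by this read-out.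

Compound 3 `CCOC(CC(=O)O)c1ccc(OCc2cccc(C)c2)cc1` has not been measured yet. It is built from the same atoms as compound 2, joined differently: 3-methylphenyl in place of 2-methylphenyl on a saturated chain carbon bound to an oxygen on an aromatic ring. Only the position of a single methyl group on the benzyl ring moves; the acid, the ether oxygen and the rest of the molecule stay untouched.

Among the measured compounds shown here, no measured pair differing only in this way is available, so the size of the step cannot be read from the present data. The expectation for compound 3 is a modest shift toward higher numbers, estimated as a 1.8-fold higher number from compound 2 to compound 3 (0.24 log units; within the scatter) in this assay. Compound 3 is accordingly expected to give about 35 nM in this assay, with a range from 12 nM to 100 nM.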

Compound 3, half-maximal effective concentration in the Free fatty acid receptor 1 assay: 35 nM
For compound 3 middle estimate and measured number coincide at the digits printed, within the range that was stated.
By their numbers in the Free fatty acid receptor 1 assay, from the lowest: compounds 2, 3 and 1 (each within the scatter of the next, the first and the last beyond it).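

Among the compounds shown here, in the Free fatty acid receptor 1 assay, placing 3-methylphenyl in place of 2-methylphenyl gives a 1.8-fold higher number from compound 2 to compound 3 (0.24 log units; within the scatter), the first direct reading of a change at this position. In the Free fatty acid receptor 1 assay compound 2 gives 20 nM and compound 3 gives 35 nM. This one pair therefore shows that the read-out does not tell these two placements of the methyl group apart, so the activity seen with compound 2 does not hang on the methyl sitting exactly where it does there. The data offer no information on why the two placements read alike.

For the compounds shown here, in a physicochemical assay for lipophilicity, at pH 7.4 (on this read-out lower numbers stand for lower lipophilicity and higher numbers for higher lipophilicity), compound 2 gives 1.2 and compound 3 gives "not determined" (no result reported), so no step to compound 3 can be read, and how moving the methyl affects lipophilicity stays open. Also open, on these data alone, is whether the same holds for other groups on the benzyl ring, such as a methoxy group or a chlorine atom in place of the methyl, since a single pair cannot show how much change this position accepts.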